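Trimming One Fluorine from the Trifluoromethoxy Group

The compounds below may be only part of what the source reports. "The series", "measured", "known", "first", "only" and "open" are said of these compounds alone.

In an ADME assay on microsomes from liver (Rattus norvegicus) for metabolic stability, with a stated time of 10 min (a lower number here means that less of the compound is left, a higher number that more of the compound is left), compound 1 `Fc1ccccc1-c1ccc2[nH]c(C3=NOC4(CCCCC4)C3)nc2c1` gives 55%, while compound 2 `FC(F)(F)Oc1ccccc1-c1ccc2[nH]c(C3=NOC4(CCCCC4)C3)nc2c1` gives 74%, the higher of the two numbers. Compound 3 `FC(F)Oc1ccccc1-c1ccc2[nH]c(C3=NOC4(CCCCC4)C3)nc2c1` has not yet been measured. It differs from compound 2 at one spot: hydrogen in place of fluoro on a saturated chain carbon bound to two fluorine atoms and an oxygen on an aromatic ring, which turns trifluoromethoxy into difluoromethoxy. Among the measured compounds shown here, only one measured step bears on this change: a number 19 percentage points higher from compound 1 to compound 2 (beyond the scatter), a modest rise with trifluoromethoxy in place of fluoro. Removing a single fluorine should give back only part of that rise. A small fall is therefore expected, a number 7 percentage points lower from compound 2 to compound 3 (within the scatter), possibly within the scatter. For compound 3 the estimate is 67%, with an expected range from 52% to 80%.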

Compound 3, percent of the compound remaining: 59%
Compound 3: the middle estimate sits 8 percentage points above what was measured, within the range that was stated.
By their numbers in this assay, from the lowest: compounds 1 and 3 (each within the scatter of the next); then compound 2.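

In this assay, swapping one fluoro for hydrogen gives a number 15 percentage points lower from compound 2 to compound 3 (beyond the scatter) and shows that the third fluorine on this carbon counts: difluoromethoxy does not keep the level of trifluoromethoxy. Difluoromethoxy in place of fluoro on the aromatic carbon gives a number 4 percentage points higher from compound 1 to compound 3 (within the scatter) and so does not separate from fluoro, leaving trifluoromethoxy alone above it. Nothing available here explains why one atom makes this difference. As far as these compounds go, whether plain methoxy or a longer chain such as ethoxy would fall nearer compound 2 or compound 3 remains open.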